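Swapping hexylsulfanyl for propoxy in a cytotoxicity test

This account rests on a few compounds, and the source may have more. Where it says the series, first, only, none or still open, it means among the compounds named here.

Compound 1 `CNc1nc(N)nc2c1ncn2/C=C1/CC1(CO)CO`: > 20000 nM
Compound 2 `Nc1nc(NC2CCCCC2)c2ncn(/C=C3/CC3(CO)CO)c2n1`: "not determined" (no result reported)
Compound 3 `CCCCCCSc1nc(N)nc2c1ncn2/C=C1/CC1(CO)CO`: > 20000 nM

In an ADME assay on MOLT-3 cells (Homo sapiens) for cytotoxicity, with a stated time of 7 days (on this read-out lower numbers stand for higher toxicity in this test and higher numbers for lower toxicity in this test), compound 3 gives > 20000 nM, which is a limit of the assay and not a number. Compound 1 gives > 20000 nM, which is also a limit. For compound 2 the entry reads "not determined" (no result reported). So compound 3 has no exact value to start from.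

Compound 4 `CCCOc1nc(N)nc2c1ncn2/C=C1/CC1(CO)CO` differs from compound 3 by a single change: propoxy in place of hexylsulfanyl on an aromatic carbon. It carries propoxy in place of hexylsulfanyl on an aromatic carbon.

Among the compounds with values here, only one measured step bears on this, a step that the two limits leave unreadable from compound 1 to compound 3, and it has no readable size. The remaining evidence is the limit of > 20000 nM in this assay, at which 2 of the 3 values shown sit. No direction can therefore be expected, and another limit is the most likely report from this assay. The expected change is a step that the limit leaves unreadable from compound 3 to compound 4, with no shift beyond the scatter foreseen. For compound 4 the estimated value is 25000 nM, with an expected range from 10000 nM to 60000 nM.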

Compound 4, half-maximal cytotoxic concentration: > 20000 nM
Compound 4: only a limit was reported (the forecaster's own chance of this, stated with the estimate: 85%); the middle value lies beyond the limit too.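

Compound 1, compound 3 and compound 4 are each reported only as a limit in this assay, and the steps among them cannot be read. The compounds shown leave open whether propoxy, hexylsulfanyl or methylamino on the shared core makes any difference to toxicity in this test.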